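A few compounds are considered here, and "the series" means these few. Any claim that something is new, unique, unknown or untested is made for them only; others in the source may bear on it.

Measured compounds in an ADME assay on MT4 cells (Homo sapiens) for cytotoxicity, read by MTT assay; a lower number here means that less compound is tolerated, a higher number that more compound is tolerated:
compound 1 `Cc1ccc(NC(=O)CSc2nncnc2-c2cccc3ccccc23)c(Br)c1`, giving 166000 nM
compound 2 `O=C(CSc1nncnc1-c1cccc2ccccc12)Nc1ccc(Cl)cc1Cl`, giving 254000 nM

Compound 1 holds the lower of the two numbers in this assay , with compound 2 nearest through a 1.5-fold higher number from compound 1 to compound 2 (0.18 log units; within the scatter).

Compound 3 `CCOC(=O)c1ccc(NC(=O)CSc2nncnc2-c2cccc3ccccc23)c(Br)c1` is not yet measured. It differs from compound 1 by ethoxycarbonyl in place of methyl on an aromatic carbon. Going by the values given here, no measured step touches this position; the only step at hand, a 1.5-fold higher number from compound 1 to compound 2 (0.18 log units; within the scatter), swaps the whole aryl group and stays within the scatter, so nothing beyond scatter is expected here either. Compound 3 is expected to give 180000 nM, between 90000 nM and 360000 nM, an expected step of a 1.1-fold higher number from compound 1 to compound 3 (0.04 log units; within the scatter).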

Compound 3, half-maximal cytotoxic concentration: 105000 nM
For compound 3 the middle estimate is 1.7-fold (0.23 log units) above the measured one; the measured number falls inside the stated range.
By their numbers in this assay, from the lowest: compounds 3, 1 and 2 (each within the scatter of the next, the first and the last beyond it).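

Putting ethoxycarbonyl in place of methyl on this aromatic carbon, meta to a bromo group, gives a 1.6-fold lower number from compound 1 to compound 3 (0.20 log units; within the scatter) in this assay. This position therefore carries a group of 5 heavy atoms with 2 hydrogen-bond acceptors without a shift beyond the scatter, something the earlier pair, which swaps the whole aryl group, could not show. Nothing available bears on this result. On these data alone, whether an amine or a carboxylic acid on this carbon would also stay within the scatter remains open. So does the effect of replacing the bromo group while ethoxycarbonyl stays in place.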